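This account rests on a few compounds, and the source may have more. Where it says the series, first, only, none or still open, it means among the compounds named here.

Measured compounds:
compound 1, `CCN(Cc1ccccc1)C(=O)COc1ccc(C)cc1`, with 1880 nM
compound 2, `CCN(Cc1cccs1)C(=O)c1cc2cc(OC)ccc2o1`, with 80 nM

Of the compounds shown here, two have been measured in an assay on HEK293 cells for agonist activity at transient receptor potential cation channel subfamily M member 8 (Homo sapiens), read by fluorescence and calcium flux, with a stated time of 15 min; on this read-out lower numbers stand for an effect already at smaller amounts and higher numbers for an effect only at larger amounts of compound. Compound 1 gives 1880 nM, the higher of the two numbers; compound 2 gives 80 nM, and the gap between them lies beyond the usual scatter. These two differ in several places at once, so no single change can be read from that gap. Compound 3, `CCN(Cc1ccncc1)C(=O)COc1ccc(C)cc1`, differs from compound 1 in one place only: pyridin-4-yl in place of phenyl on a saturated chain carbon bound to an amide-type nitrogen. Among the measured compounds shown here, no measured pair shows this change, so its effect is unknown here. The ring that leaves and the ring that enters are both six-membered aromatic rings; a modest shift in this assay is expected, in either direction, and possibly none beyond the scatter. Compound 3 is expected to give about 2500 nM, with a range from 800 nM to 8000 nM. That estimate corresponds to a step of a 1.3-fold higher number from compound 1 to compound 3 (0.12 log units; within the scatter), expected to be small.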

Compound 3, half-maximal effective concentration: "not active" (no number reported)
The entry for compound 3 holds no number, so the estimate cannot be set against anything.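

In this assay compound 3 has no number, so no step from compound 1 to compound 3 can be read, and nothing shown here accounts for this result. Going by these compounds, how far pyridin-4-yl in place of phenyl shifts the number remains open.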